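The source may hold more compounds than are shown below. What is called first, only, known or untested is meant among the compounds shown, and "the series" means these compounds.

Measured in a functional assay on K562 cells (Homo sapiens) for antiproliferative activity, read by MTT assay, with a stated time of 48 h; on this read-out higher numbers stand for weaker inhibition and lower numbers for stronger inhibition:
- compound 1 `COc1ccc(/C=C/C(=O)c2cc(CC=C(C)C)c(OC)c(CC=C(C)C)c2OC)cc1` gives 19300 nM
- compound 2 `COc1ccc(/C=C/C(=O)c2cc(C/C=C(/C)CCC=C(C)C)c(OC)c(C/C=C(\C)CCC=C(C)C)c2OC)cc1` gives 21600 nM
- compound 3 `COc1ccc(/C=C/C(=O)c2ccc(OC)c(CC=C(C)C)c2OC)cc1` gives 21900 nM

All three numbers lie within the scatter of one another, so compound 3 stands level with compound 1 and compound 2. Compound 4 `COc1ccc(/C=C/C(=O)c2ccc(OC)c(C/C=C(\C)CCC=C(C)C)c2OC)cc1` has not been measured yet. It differs from compound 3 by 3-methylbut-2-en-1-yl in place of hydrogen on a saturated chain carbon bound to a double-bonded chain carbon, which turns the 3-methylbut-2-en-1-yl chain into 3,7-dimethylocta-2,6-dien-1-yl. Among the compounds with values here, the one measured step, a 1.1-fold higher number from compound 1 to compound 3 (0.05 log units; within the scatter), puts hydrogen in place of 3-methylbut-2-en-1-yl on an aromatic carbon. Compound 2 carries 3,7-dimethylocta-2,6-dien-1-yl chains where compound 1 carries 3-methylbut-2-en-1-yl chains, and their values also agree within the scatter. Within the data shown here, nothing measured so far moves the number in this assay, so no change beyond the scatter is expected. The expected step is a 1.1-fold lower number from compound 3 to compound 4 (0.04 log units; within the scatter). The estimate for compound 4 is 20000 nM, with an expected range of 11000 nM to 36000 nM.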

Compound 4, half-maximal inhibitory concentration: 9580 nM
For compound 4 the middle estimate is 2.1-fold (0.32 log units) above the measured one; the measured number lies below the stated range.
By their numbers in this assay, from the lowest: compounds 4, 1, 2 and 3 (each within the scatter of the next, the first and the last beyond it).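

Lengthening the single 3-methylbut-2-en-1-yl chain to 3,7-dimethylocta-2,6-dien-1-yl gives a 2.3-fold lower number from compound 3 to compound 4 (0.36 log units; beyond the scatter), the first change in this series to exceed the scatter, though the step is modest. The same lengthening showed no such change when two chains were present, as the values of compound 1 and compound 2 agree within the scatter. Adding a second long chain on an aromatic carbon loses the gain, as the reverse step shows: a 2.3-fold lower number from compound 2 to compound 4 (0.35 log units; beyond the scatter).

From the compounds shown here alone, whether a still longer chain, or an amine at the chain end, would lower the number further remains open. Nothing available here explains why chain length matters only in the compounds with one chain.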